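A few compounds are considered here, and "the series" means these few. Any claim that something is new, unique, unknown or untested is made for them only; others in the source may bear on it.

Compound 1, `COc1ccc(S(=O)(=O)N(C)CCOCC(=O)N(C)Cc2ccc(C3=NCCN3)cc2)c(C)c1`, is one of two compounds with a result in an assay on HEK293 cells for displacement of a labelled ligand from B1 bradykinin receptor (Homo sapiens), read by scintillation counting; a higher number here means a weaker inhibitor, a lower number a stronger inhibitor; in this assay compound 1 gives 5.5 nM. The other compound, compound 2, `COc1cc(C)c(S(=O)(=O)N(C)CCOCC(=O)N2CCN(CC3CCN(C)CC3)CC2)c(C)c1`, gives 4.5 nM in this assay, and the two numbers sit within the scatter of each other, so no order between compound 1 and compound 2 can be read from them. Compound 3, `Cc1c(Cl)cccc1S(=O)(=O)N(C)CCOCC(=O)N(C)Cc1ccc(C2=NCCN2)cc1`, has not yet been measured. It differs from compound 1 in one place: 3-chloro-2-methylphenyl in place of 4-methoxy-2-methylphenyl on a sulfonyl sulfur. Within the data shown here, no pair of measured compounds shows a step of this kind, so the effect of exchanging a methoxy-bearing ring for a chlorine-bearing ring on the sulfonyl sulfur remains to be seen. Compound 3 is expected to stay in the same region as compound 1, and the step of a 1.5-fold higher number from compound 1 to compound 3 (0.16 log units; within the scatter) is expected to be small, with no clear direction beyond the scatter. Compound 3 is estimated to give 8 nM in this assay, with a range from 2 nM to 30 nM.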

Compound 3, inhibition constant: 6.8 nM
The estimate for compound 3 lay 1.2-fold (0.07 log units) above the measured number; low and high end bracket the measured number.
By their numbers in this assay, from the lowest: compounds 2, 1 and 3 (each within the scatter of the next).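

In this assay, among these compounds, the first exchange on the ring at the sulfonyl sulfur, with the rest of compound 1 held constant, gives a 1.2-fold higher number from compound 1 to compound 3 (0.09 log units; within the scatter). The two numbers therefore cannot be ordered: this position accepts 3-chloro-2-methylphenyl as well as 4-methoxy-2-methylphenyl, even though the entering group has no hydrogen-bond acceptor and the leaving group has one. No measurement shown here explains why the two rings read alike.

This single step cannot separate the loss of the methoxy group from the arrival of the chlorine, and it does not show whether the same exchange would read alike on the core of compound 2. It also leaves open how the position would respond to a ring carrying an amine or a carboxylic acid, or to a pyridine ring in place of the benzene ring.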